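The source may report more compounds than this note shows. Statements on the series, on what has been measured and on what is new or still open speak of the compounds shown alone.

Compound 1 `O=S1(=O)C=Cc2ccc(Nc3cccc(OC(F)(F)F)c3)cc21` – 1370 nM in the assay below
Compound 2 `O=S1(=O)C=Cc2cccc(Nc3ccc(OC(F)(F)F)cc3)c21` – 1570 nM in the assay below

In a functional assay on A549 cells (Homo sapiens) for antiproliferative activity, read by MTT assay, with a stated time of 72 h (on this read-out higher numbers stand for weaker inhibition and lower numbers for stronger inhibition), compound 2 stands at 1570 nM and lies within the scatter of compound 1 at 1370 nM on this read-out. Compound 3 `O=S1(=O)C=Cc2cccc(Nc3ccc(C(F)(F)F)cc3)c21` carries trifluoromethyl in place of trifluoromethoxy on an aromatic carbon, para to a large group (trifluoromethyl in place of trifluoromethoxy on an aromatic carbon). Among the compounds with values here, no measured pair shows this change, so in this assay no step beyond the scatter is expected, in either direction. The estimated move is small a 1.1-fold higher number from compound 2 to compound 3 (0.03 log units; within the scatter) and stays inside the scatter. Compound 3 is expected at 1700 nM, with an estimated range of 600 nM to 4500 nM.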

Compound 3, half-maximal inhibitory concentration: 2440 nM
Compound 3: the middle estimate sits 1.4-fold (0.16 log units) below what was measured; the measured number falls inside the stated range.
By their numbers in this assay, from the lowest: compounds 1, 2 and 3 (each within the scatter of the next).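

Placing trifluoromethyl in place of trifluoromethoxy on an aromatic carbon, para to a large group, gives in this assay the first reading of this change: a 1.6-fold higher number from compound 2 to compound 3 (0.19 log units; within the scatter). At this position, the read-out therefore does not separate the two groups, and the oxygen of trifluoromethoxy can go without a step beyond the scatter. No measurement shown here offers an explanation for this result.

Going by these compounds, it remains open whether an amine or a carboxylic acid at this position would move the number beyond the scatter. On these data alone, it is also open whether the same change would read alike on the core of compound 1.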